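Swapping the hexyl tail of compound 2 for an acetamido chain

A few compounds are considered here, and "the series" means these few. Any claim that something is new, unique, unknown or untested is made for them only; others in the source may bear on it.

Measured compounds:
compound 1 `Nc1cn([C@H]2C[C@H](O)[C@@H](CO)O2)c(=O)[nH]c1=O`: 450000 nM
compound 2 `CCCCCCNC[C@H]1O[C@@H](n2cc(C)c(=O)[nH]c2=O)C[C@@H]1O`: 180000 nM

In an assay on BHK21 (C13) cells (Mesocricetus auratus) for inhibition of thymidine kinase, cytosolic (Cricetulus griseus), using Lineweaver-Burk analysis (a lower number here means a stronger inhibitor, a higher number a weaker inhibitor), compound 1 gives 450000 nM and compound 2 gives 180000 nM. Of these two numbers compound 2 holds the lower one, with compound 1 standing beyond the scatter above it. Compound 3 `CC(=O)NCCNC[C@H]1O[C@@H](n2cc(C)c(=O)[nH]c2=O)C[C@@H]1O` is not yet measured in this assay; it differs from compound 2 by acetamido in place of butyl on a saturated chain carbon, two bonds along the chain from an amine nitrogen. For the measured compounds named here, no step between measured compounds covers a change of this kind, so the direction is open. Compound 3 is expected to give about 300000 nM (range 100000 nM to 900000 nM), and the expected step from compound 2 to compound 3 is a 1.7-fold higher number from compound 2 to compound 3 (0.22 log units; within the scatter), which may well stay within the scatter.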

Compound 3, inhibition constant: 250000 nM
Compound 3: the middle estimate sits 1.2-fold (0.08 log units) above what was measured; the range from low to high includes it.
By their numbers in this assay, from the lowest: compounds 2, 3 and 1 (each within the scatter of the next, the first and the last beyond it).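

In this assay, acetamido in place of butyl on a saturated chain carbon, two bonds along the chain from an amine nitrogen, gives a 1.4-fold higher number from compound 2 to compound 3 (0.14 log units; within the scatter), so compound 2 and compound 3 cannot be told apart. At this position, the hydrogen-bond donor and acceptor that enter with acetamido leave the inhibition constant within the scatter. Nothing available explains this result. Going by these compounds, whether a carboxylic acid, an amine or a longer chain at this place would move the number beyond the scatter remains open.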